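The source may hold more compounds than are shown below. What is called first, only, known or untested is meant among the compounds shown, and "the series" means these compounds.

In a functional assay on MCF7 cells (Homo sapiens) for antiproliferative activity, read by MTT assay, with a stated time of 24 h (on this read-out lower numbers stand for stronger inhibition and higher numbers for weaker inhibition), the measured members of the series are:

compound 1 `COc1ccc(C(=O)NNC(=O)/C=C/c2ccc(O)cc2)cc1`, 6020 nM
compound 2 `O=C(/C=C/c1ccc(O)cc1)NNC(=O)c1ccc(O)cc1`, 8800 nM
compound 3 `COc1cc(/C=C/C(=O)NNC(=O)c2ccccc2)ccc1O`, 5220 nM

Compound 1 and compound 2 differ by one change, (hydrogen in place of methyl on an oxygen on an aromatic ring); on this assay it made a step of a 1.5-fold higher number from compound 1 to compound 2 (0.16 log units; within the scatter). The difference between the core of compound 1 and the core of compound 3 is not broken down here. Compound 4 `O=C(/C=C/c1ccc(O)c(O)c1)NNC(=O)c1ccccc1` has not been measured; it stands to compound 3 as compound 2 stands to compound 1, namely by the same change, (hydrogen in place of methyl on an oxygen on an aromatic ring). The expected step in this assay is a 1.4-fold higher number from compound 3 to compound 4 (0.16 log units; within the scatter), which rests on the step seen from compound 1 to compound 2 being within the scatter. Compound 4 is therefore expected near 7500 nM, with a range of 3500 nM to 16000 nM.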

Compound 4, half-maximal inhibitory concentration: 4750 nM
The estimate for compound 4 lay 1.6-fold (0.20 log units) above the measured number, and the stated range covers the measured number.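

In this assay, replacing methoxy with hydroxy on the second core gave a 1.1-fold lower number from compound 3 to compound 4 (0.04 log units; within the scatter). Set beside the first core, the change shows no measurable dependence on the core: the same change on two cores in this assay, a 1.5-fold higher number (0.16 log units; within the scatter) from compound 1 to compound 2 and a 1.1-fold lower number (0.04 log units; within the scatter) from compound 3 to compound 4, 1.6-fold (0.21 log units) apart, within the scatter of two such steps This supports treating methoxy and hydroxy as interchangeable at these places on these two cores in this assay, but it rests on only two small steps and does not show that the change is neutral on other cores or in other assays.

Open, on these data alone, is whether a larger group on this oxygen, such as ethoxy or a longer chain, would produce a step beyond the scatter. Also open, as far as these compounds go, is whether an amine or a carboxylic acid in place of hydroxy would do so.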